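The source may hold more compounds than are shown below. What is called first, only, known or untested is meant among the compounds shown, and "the series" means these compounds.

Measured so far:
Compound 1 `COc1ccc(C2=C(c3cc(OC)c(OC)c(OC)c3)C(=O)C(O)C2)cc1` is recorded in an ADME assay on HEp-2 cells (Homo sapiens) for cytotoxicity, read by MTT assay, with a stated time of 72 h (on this read-out lower numbers stand for stronger inhibition and higher numbers for weaker inhibition), only as a limit of the assay, < 1 ug/mL.
Compound 2 `COc1ccc(C2=C(c3cc(OC)c(OC)c(OC)c3)CC(O)C2=O)cc1[N+](=O)[O-]` is likewise recorded in this assay only as a limit, > 100 ug/mL.
Compound 3 `COc1ccc(C2=C(c3cc(OC)c(OC)c(OC)c3)C(=O)C(O[SiH2]C(C)(C)C)C2)cc1` gives in this assay a number, 16 ug/mL.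

Compound 3 arises from compound 1 by a group of 5 heavy atoms (4 carbon, 1 silicon; no ring) in place of a hydrogen atom, on an oxygen on a saturated carbon, and this step is an at least 16-fold higher number from compound 1 to compound 3 (1.20 log units; beyond the scatter); that size rests on compound 1 standing at the limit of < 1 ug/mL in this assay, at which 1 of the 3 values shown sits. How the core of compound 2 differs from the core of compound 1 is not broken down here. Compound 4 `COc1ccc(C2=C(c3cc(OC)c(OC)c(OC)c3)CC(O[SiH2]C(C)(C)C)C2=O)cc1[N+](=O)[O-]` is not yet measured; it arises from compound 2 by the same change, (a group of 5 heavy atoms (4 carbon, 1 silicon; no ring) in place of a hydrogen atom, on an oxygen on a saturated carbon). Beside an at least 16-fold higher number from compound 1 to compound 3 (1.20 log units; beyond the scatter), a step that the limit leaves unreadable from compound 2 to compound 4 is expected, because compound 2 already stands at the limit of > 100 ug/mL in this assay, at which 1 of the 3 values shown sits, and the earlier step raised the number. Compound 4 is therefore estimated at 150 ug/mL, with a range from 50 ug/mL to 600 ug/mL, most likely again reported as a limit.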

Compound 4, half-maximal inhibitory concentration: > 100 ug/mL
Compound 4: only a limit was reported; the forecaster's own chance of this, stated with the estimate: 85%; the middle value lies beyond the limit too.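

Compound 2 and compound 4 both stand only as limits, so the step between them cannot be read: the limit of > 100 ug/mL in this assay, at which 2 of the 4 values shown sit. On these data alone, whether the added group changes the number on the core of compound 2 stays open.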